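A Cyano Group Enters a Series Stuck at the Limit

The source may hold more compounds than are shown below. What is called first, only, known or untested is meant among the compounds shown, and "the series" means these compounds.

Of the compounds shown here, three have been tested in an assay on HL-60 cells for agonist activity at N-formyl peptide receptor 3 (Homo sapiens), read by calcium flux; a lower number here means that less compound is needed, a higher number that more compound is needed for the effect. Compound 1, `COc1cccc(Cc2cc(-c3ccc(F)cc3)nn(CC(=O)Nc3ccc(F)cc3)c2=O)c1`, gives > 50000 nM, which is a limit of the assay and not a number. Compound 2, `Cc1cc(Cc2ccccc2)c(=O)n(CC(=O)Nc2ccc(Br)cc2)n1`, likewise gives a limit, > 50000 nM. Compound 3, `Cc1cc(Cc2ccccc2)c(=O)n(CC(=O)Nc2ccc(F)cc2)n1`, also gives a limit, > 50000 nM. Compound 2 thus stands at the limit of the assay, and the two other values shown stand there too. The step from compound 2 to compound 3, fluoro in place of bromo on an aromatic carbon, is a step that the two limits leave unreadable from compound 2 to compound 3 because of the limit of > 50000 nM in this assay, at which 3 of the 3 values shown sit. Compound 4, `Cc1cc(Cc2ccc(C#N)cc2)c(=O)n(CC(=O)Nc2ccc(Br)cc2)n1`, differs from compound 2 by cyano in place of hydrogen on an aromatic carbon. Among the compounds with values here, no measured step involves a cyano group, so the expectation rests only on the observation that every value shown sits at the limit, with none of compounds 1, 2 or 3 going against it. Compound 4 is therefore expected to stay near the limit, with an expected step that the limit leaves unreadable from compound 2 to compound 4. The estimate for compound 4 is 60000 nM, ranging from 15000 nM to 300000 nM.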

Compound 4, half-maximal effective concentration: > 50000 nM
Compound 4 ended at the assay's limit; the forecaster's own chance of this, stated with the estimate: 80%; the middle value lies beyond the limit too.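

No size can be read for the change from compound 2 to compound 4, because both compounds sit at a limit and not at a number: the limit of > 50000 nM in this assay, at which 4 of the 4 values shown sit.

The compounds shown leave open whether any structure of this kind gives a readable value in this assay, and so whether the cyano group changes anything.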